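The source may hold more compounds than are shown below. What is called first, only, known or untested is meant among the compounds shown, and "the series" means these compounds.

Compound 1 `Cc1ccc(NC(=O)c2cccc(/C=C3\CC(=O)N(c4ccccc4)C3=O)c2)cc1` was examined in an ADME assay on HCT-116 cells (Homo sapiens) for cytotoxicity, read by MTT assay, with a stated time of 72 h; on this read-out higher numbers stand for weaker inhibition and lower numbers for stronger inhibition. In this assay compound 1 reaches only the limit > 100000 nM, an edge of the assay rather than a number. Compound 2 `CCc1cccc(NC(=O)c2cccc(/C=C3\CC(=O)N(c4ccccc4)C3=O)c2)c1` gives 81200 nM in this assay. Compound 3 `COc1ccc(NC(=O)c2cccc(/C=C3\CC(=O)N(c4ccc(C)cc4)C3=O)c2)cc1` also reaches only the limit > 100000 nM in this assay. Most of these values sit at that edge (the limit of > 100000 nM in this assay, at which 2 of the 3 values shown sit). Among the measured compounds shown here, the one measured step, an at least 1.2-fold lower number from compound 1 to compound 2 (0.09 log units; that floor lies within the scatter), swaps the group on the amide-type nitrogen and stays within the scatter. For the measured compounds named here, compound 4 `O=C(NCC1CCCCC1)c1cccc(/C=C2\CC(=O)N(c3ccccc3)C2=O)c1` differs from compound 1 by cyclohexylmethyl in place of 4-methylphenyl on an amide-type nitrogen; no measured step covers this change. For compound 4 the step of a number no higher from compound 1 to compound 4 (the limit leaves the size open) is expected, nothing beyond the scatter. Compound 4 is estimated at 100000 nM, between 40000 nM and 300000 nM, with a fair chance that only a limit is reported again.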

Compound 4, half-maximal inhibitory concentration: > 100000 nM
Compound 4: no number, only a limit; the forecaster's own chance of this, stated with the estimate: 60%; the middle value sits exactly at the limit.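

Compound 4 gives only a limit, > 100000 nM, so with cyclohexylmethyl a non-aromatic ring on this amide-type nitrogen joins the aromatic groups without yielding a number in this assay. Among the compounds shown here, the step between compound 1 and compound 4 cannot be read, as both values are limits, and the one readable step, an at least 1.2-fold higher number from compound 2 to compound 4 (0.09 log units; that floor lies within the scatter), stays within the scatter. The series now gathers even more at one edge: the limit of > 100000 nM in this assay, at which 3 of the 4 values shown sit.

As far as these compounds go, how an amine or a carboxylic acid on the group at this nitrogen would read stays open. Also open, from the compounds shown here alone, is whether any change here moves the number beyond the scatter.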